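Sulfonyl aryl exchange on a trifluoromethyl core

The source may report more compounds than this note shows. Statements on the series, on what has been measured and on what is new or still open speak of the compounds shown alone.

Measured compounds:
compound 1 `COc1ccc(S(=O)(=O)n2c(-c3cn(-c4ccccc4)nc3-c3ccc(F)cc3)nc3ccccc32)cc1` with 37300 nM
compound 2 `Cc1ccc(C)c(S(=O)(=O)n2c(-c3cn(-c4ccccc4)nc3-c3ccc(F)cc3)nc3ccccc32)c1` with 54200 nM
compound 3 `COc1ccc(S(=O)(=O)n2c(-c3cn(-c4ccccc4)nc3-c3ccc(C(F)(F)F)cc3)nc3ccccc32)cc1` with > 300000 nM

Of the compounds shown here, three have been tested in an ADME assay on HEK-293T cells (Homo sapiens) for cytotoxicity, read by MTT assay, with a stated time of 24 h; a lower number here means that less compound is tolerated, a higher number that more compound is tolerated. Compound 1 `COc1ccc(S(=O)(=O)n2c(-c3cn(-c4ccccc4)nc3-c3ccc(F)cc3)nc3ccccc32)cc1` gives 37300 nM. Compound 2 `Cc1ccc(C)c(S(=O)(=O)n2c(-c3cn(-c4ccccc4)nc3-c3ccc(F)cc3)nc3ccccc32)c1` gives 54200 nM, and the change between them is 2,5-dimethylphenyl in place of 4-methoxyphenyl on a sulfonyl sulfur, which moved the number by a 1.5-fold higher number from compound 1 to compound 2 (0.16 log units; within the scatter). For compound 3 `COc1ccc(S(=O)(=O)n2c(-c3cn(-c4ccccc4)nc3-c3ccc(C(F)(F)F)cc3)nc3ccccc32)cc1` the assay reports only a limit, > 300000 nM, which is the limit of > 300000 nM in this assay, at which 1 of the 3 values shown sits. Compound 3 differs from compound 1 by trifluoromethyl in place of fluoro on an aromatic carbon, and that step is an at least 8.0-fold higher number from compound 1 to compound 3 (0.90 log units; beyond the scatter).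

Compound 4 `Cc1ccc(C)c(S(=O)(=O)n2c(-c3cn(-c4ccccc4)nc3-c3ccc(C(F)(F)F)cc3)nc3ccccc32)c1` has not yet been measured. It stands to compound 3 as compound 2 stands to compound 1: the change is 2,5-dimethylphenyl in place of 4-methoxyphenyl on a sulfonyl sulfur, the same change at the same place, made twice among these compounds. Because the first instance gave a 1.5-fold higher number from compound 1 to compound 2 (0.16 log units; within the scatter), within the scatter, the step from compound 3 to compound 4 is expected to be similar, about a step that the limit leaves unreadable from compound 3 to compound 4. Since compound 3 already sits at the limit (the limit of > 300000 nM in this assay, at which 1 of the 3 values shown sits), compound 4 is expected to come out around 450000 nM, most likely again reported only as a limit, with a plausible range of 150000 nM to 1500000 nM.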

Compound 4, half-maximal cytotoxic concentration: 223000 nM
For compound 4 the middle estimate is 2.0-fold (0.30 log units) above the measured one, within the range that was stated.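

In this assay the exchange of 4-methoxyphenyl for 2,5-dimethylphenyl on the trifluoromethyl compounds gives an at least 1.3-fold lower number from compound 3 to compound 4 (0.12 log units; that floor lies within the scatter) and, as the reading for compound 3 is a limit, only a floor can be read, so agreement with the fluoro pair stays unsettled: the same change on two cores in this assay, a 1.5-fold higher number (0.16 log units; within the scatter) from compound 1 to compound 2 and an at least 1.3-fold lower number (0.12 log units; that floor lies within the scatter) from compound 3 to compound 4; the limit leaves it open whether they differ. Trifluoromethyl in place of fluoro gives a 4.1-fold higher number from compound 2 to compound 4 (0.61 log units; beyond the scatter) and so raises the number with both sulfonyl aryl groups, beyond the scatter each time: the same change on two cores in this assay, an at least 8.0-fold higher number (0.90 log units; beyond the scatter) from compound 1 to compound 3 and a 4.1-fold higher number (0.61 log units; beyond the scatter) from compound 2 to compound 4; the limit leaves it open whether they differ. This shows the direction of the trifluoromethyl change carrying from one core to the other, but it does not show that its size carries, nor that the sulfonyl exchange behaves alike on both.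

The compounds shown leave open whether the trifluoromethyl change keeps its direction with other groups on the sulfonyl sulfur, such as an aryl carrying an amine or a carboxylic acid. They also leave open what a chloro or a nitrile would do in place of trifluoromethyl on that aromatic carbon.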